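From compound 3 to compound 4: fluoro for methoxy

The source may report more compounds than this note shows. Statements on the series, on what has been measured and on what is new or still open speak of the compounds shown alone.

In an ADME assay on THP-1 cells (Homo sapiens) for cytotoxicity, read by flow cytometry and propidium iodide staining, with a stated time of 72 h (a higher number here means a weaker inhibitor, a lower number a stronger inhibitor), compound 1 (`CC(=O)Nc1ccc(O)c(C(=O)/C=C/c2cccc(F)c2)c1`) gives 78600 nM and compound 2 (`CC(=O)Nc1ccc(O)c(C(=O)/C=C/c2ccc(F)cc2)c1`) gives 68800 nM in the same range. Compound 3 (`COc1cccc(-c2cc(=O)c3cc(NC(C)=O)ccc3o2)c1`) gives 10000 nM as the lowest number of the three, beyond the scatter from both others. Compound 4 (`CC(=O)Nc1ccc2oc(-c3cccc(F)c3)cc(=O)c2c1`) has fluoro in place of methoxy on an aromatic carbon. Within the data shown here, no measured pair covers this exchange. Among the measured compounds shown here, the only measured step (a 1.1-fold lower number from compound 1 to compound 2 (0.06 log units; within the scatter)) lies within the scatter and is a different exchange, so it bears only weakly, and no change beyond the scatter is expected for compound 4. The expected step (a 1.4-fold higher number from compound 3 to compound 4 (0.15 log units; within the scatter)) stays within the scatter. In this assay the estimate for compound 4 is 14000 nM (expected range 6000 nM to 35000 nM).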

Compound 4, half-maximal inhibitory concentration: > 125000 nM
Compound 4 gave a limit, no number; the forecaster's own chance of this, stated with the estimate: 15%; at least 8.9-fold (0.95 log units) between middle value and limit.
By their numbers in this assay, from the lowest: compound 3; then compounds 2 and 1 (each within the scatter of the next). At a limit, above all of these: compound 4.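

In this assay, the aromatic carbon meta to a large group is sensitive to this exchange: fluoro in place of methoxy gives an at least 12-fold higher number from compound 3 to compound 4 (1.09 log units; beyond the scatter) and so marks this place as one where a single small exchange matters. The other one-place step shown is a 1.1-fold lower number from compound 1 to compound 2 (0.06 log units; within the scatter) and gives no such change. From the compounds shown here alone, compound 4 reads as a limit and not a number, so the full size of its step stays unknown: the limit of > 125000 nM in this assay, at which 1 of the 4 values shown sits.

Open, going by these compounds, is whether a hydroxy group, a chlorine or an amine at this place would read like methoxy or like fluoro. Also open, on these data alone, is whether a longer alkoxy chain would keep the lower number of compound 3.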